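Swapping a Benzyl Ring for Imidazole on a Sugar Core

This account rests on a few compounds, and the source may have more. Where it says the series, first, only, none or still open, it means among the compounds named here.

Two compounds built on a sugar core carrying a flexible amine chain have been measured in an assay on isolated protein for binding affinity to somatostatin receptor type 4 (Homo sapiens); a lower number here means a stronger inhibitor, a higher number a weaker inhibitor. Compound 1 `NCCCCCOC[C@H]1O[C@@H](OCCc2c[nH]c3ccccc23)[C@H](OCc2ccccc2)C[C@@H]1OCc1ccccc1` gives 1700 nM in this assay. Compound 2 `CO[C@@H]1O[C@H](COCCCCCN)[C@@H](OCc2ccccc2)[C@H](OCc2ccccc2)[C@H]1OCc1ccccc1` gives 2000 nM in this assay; this number lies within the usual scatter of that for compound 1, so the two cannot be told apart. Compound 3 `NCCCCCOC[C@H]1O[C@@H](OCCc2c[nH]c3ccccc23)[C@H](OCc2c[nH]cn2)C[C@@H]1OCc1ccccc1` is not yet measured. It differs from compound 1 in one place: 1H-imidazol-4-yl in place of phenyl on a saturated chain carbon bound to an oxygen on a saturated carbon. Within the data shown here, no measured pair shows what such a swap does in this assay, so there is no step to lean on. The expectation for compound 3 is therefore a step of a 1.2-fold higher number from compound 1 to compound 3 (0.07 log units; within the scatter), most likely no more than the scatter, with a wide margin in both directions. Compound 3 is estimated at 2000 nM, with a range from 700 nM to 6000 nM.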

Compound 3, inhibition constant: 3000 nM
Beside the measured number, compound 3's estimate is 1.5-fold (0.18 log units) below it; low and high end bracket the measured number.
By their numbers in this assay, from the lowest: compounds 1, 2 and 3 (each within the scatter of the next).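

In this assay, the step from phenyl to 1H-imidazol-4-yl on a saturated chain carbon bound to an oxygen on a saturated carbon is a 1.8-fold higher number from compound 1 to compound 3 (0.25 log units; within the scatter), so compound 1 and compound 3 cannot be told apart. Among these compounds, this is the first direct reading of a change at this position: a ring of carbon only gave way to a five-membered ring with 2 hetero atoms, one hydrogen-bond donor and one hydrogen-bond acceptor, and no difference beyond the scatter appeared. Nothing at hand accounts for this result.

Still open, as far as these compounds go, is whether a different group here, such as a carboxylic acid, a primary amine or a longer chain ending in a phenyl ring, would move the number beyond the scatter. From the compounds shown here alone, it is also open whether replacing the remaining benzyl group on the core of compound 3 would do so.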